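This account rests on a few compounds, and the source may have more. Where it says the series, first, only, none or still open, it means among the compounds named here.

Compound 1 `COc1cc2c(Oc3ccc(NC(=O)c4nnn(-c5ccccc5C)c4C)cc3F)ccnc2cc1OCCCN1CCCC1`: 450 nM
Compound 2 `COc1cc2c(Oc3ccc(NC(=O)c4nnn(-c5ccc(F)cc5)c4C(F)(F)F)cc3F)ccnc2cc1OCCCN1CCCC1`: 120 nM

In a functional assay on HT-29 cells (Homo sapiens) for cytotoxicity, read by MTT assay, with a stated time of 72 h (a higher number here means a weaker inhibitor, a lower number a stronger inhibitor), compound 1 gives 450 nM and compound 2 gives 120 nM. Among the measured compounds shown here, of the two numbers measured so far, compound 2 has the lower one, and its gap to compound 1 lies beyond the usual scatter of repeated measurements, so compound 2 stands as the stronger inhibitor of the pair. Compound 3 `COc1cc2c(Oc3ccc(NC(=O)c4nnn(-c5ccccc5C(F)(F)F)c4C(F)(F)F)cc3F)ccnc2cc1OCCCN1CCCC1` has not yet been measured. It is built from compound 2 by a single change: 2-(trifluoromethyl)phenyl in place of 4-fluorophenyl on an aromatic nitrogen. For the measured compounds named here, no measured pair in this set shows what such a swap does, so neither the size nor the direction of the step can be read from existing numbers. The expected step is a 1.7-fold higher number from compound 2 to compound 3 (0.22 log units; within the scatter), small if anything and possibly not beyond the scatter. Compound 3 is estimated to give 200 nM in this assay, with a likely range from 60 nM to 700 nM.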

Compound 3, half-maximal inhibitory concentration: 210 nM
Beside the measured number, compound 3's estimate is 1.1-fold (0.02 log units) below it; the measured number falls inside the stated range.
By their numbers in this assay, from the lowest: compounds 2 and 3 (each within the scatter of the next); then compound 1.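

In this assay, putting 2-(trifluoromethyl)phenyl in place of 4-fluorophenyl on the aromatic nitrogen gives a 1.8-fold higher number from compound 2 to compound 3 (0.24 log units; within the scatter). Among the compounds shown here, this is the first single-place comparison in the set, and it shows that this position, next to the ring atom that bears a trifluoromethyl group, can take the larger group of 10 heavy atoms instead of 7 without a step beyond the scatter. Nothing available here explains why the step has this size.

Compound 1 differs from both other compounds in more than one place, so the separate steps to it cannot be read. Also open, going by these compounds, is how this nitrogen would tolerate something other than a substituted phenyl ring, such as a simple ethyl chain, or a phenyl ring carrying an amine or a carboxylic acid.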